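Bromo to methoxy on the saturated hydroxylated core

A few compounds are considered here, and "the series" means these few. Any claim that something is new, unique, unknown or untested is made for them only; others in the source may bear on it.

Measured compounds in a functional assay on HCT-116 cells (Homo sapiens) for antiproliferative activity, read by MTT assay, with a stated time of 72 h; on this read-out higher numbers stand for weaker inhibition and lower numbers for stronger inhibition:
compound 1 `O=C1O[C@H]([C@@H](O)Cn2cc(-c3ccc(Br)cc3)nn2)C(OCc2ccccc2)=C1OCc1ccccc1`, 9420 nM
compound 2 `COc1ccc(-c2cn(C/C=C3\OC(=O)C(OCc4ccccc4)=C3OCc3ccccc3)nn2)cc1`, > 100000 nM
compound 3 `O=C1O/C(=C\Cn2cc(-c3cccc(O)c3)nn2)C(OCc2ccccc2)=C1OCc1ccccc1`, 63600 nM

Compound 2 returns only a limit of this assay, (the limit of > 100000 nM in this assay, at which 1 of the 3 values shown sits), not a number. Of the two numbers, compound 1 has the lower one, and compound 3 stands well above it, beyond the usual scatter. Among the compounds with values here, the one measured step, an at least 1.5-fold lower number from compound 2 to compound 3 (0.19 log units; that floor lies within the scatter), leads from the limit to a number and so can only be read as a floor.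

The unmeasured compound 4 `COc1ccc(-c2cn(C[C@H](O)[C@H]3OC(=O)C(OCc4ccccc4)=C3OCc3ccccc3)nn2)cc1` keeps the core of compound 1 and changes the aryl substituent: methoxy in place of bromo on an aromatic carbon. Within the data shown here, no measured step makes this same change. The only indirect bearing is that, on the other core, the 4-methoxyphenyl compound 2 gives a limit while the 3-hydroxyphenyl compound 3 gives a number, so the methoxy aryl is the weaker of that pair by at least the step of an at least 1.5-fold lower number from compound 2 to compound 3 (0.19 log units; that floor lies within the scatter). A methoxy for bromo in this assay is therefore expected to raise the number modestly; compound 4 is expected at 25000 nM, within 8000 nM to 90000 nM, an expected step of a 2.7-fold higher number from compound 1 to compound 4 (0.42 log units; beyond the scatter).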

Compound 4, half-maximal inhibitory concentration: > 100000 nM
Compound 4 ended at the assay's limit; the forecaster's own chance of this, stated with the estimate: 10%; middle value at least 4.0-fold (0.60 log units) from the limit.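

In this assay, within the data shown here, the change from 4-bromophenyl to 4-methoxyphenyl on the core of compound 1 gives an at least 10-fold higher number from compound 1 to compound 4 (1.02 log units; beyond the scatter) and is the first direct reading of this swap, on an aromatic carbon para to a large group. Earlier, the methoxy aryl could be judged only on the other core and only against a 3-hydroxyphenyl, with a floor that stayed within the scatter; here the floor alone clears it, so the position is clearly not indifferent to this change on this core. The 4-methoxyphenyl group now ends at a limit on both cores, in compound 2 and in compound 4, and neither compound gives a number: the limit of > 100000 nM in this assay, at which 2 of the 4 values shown sit.

As far as these compounds go, since compound 4 gives only a limit, the true size of the step remains open, and the bromo-to-methoxy change cannot be compared with any other change at this position. Also open, from the compounds shown here alone, is whether a smaller halogen such as chloro, a dimethylamino group or a carboxylic acid at the same position would keep a measurable number on the core of compound 1, and how a 3-hydroxyphenyl would read on that core.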